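Chloro to cyano: first working notes on the series

This account rests on a few compounds, and the source may have more. Where it says the series, first, only, none or still open, it means among the compounds named here.

Of the compounds shown here, two have numbers so far in a functional assay on MT2 cells (Homo sapiens) for cytotoxicity, read by MTT assay; a lower number here means that less compound is tolerated, a higher number that more compound is tolerated. Compound 1 (`N#Cc1ccc(Nc2nccs2)cc1OCc1cccs1`) gives 4100 nM, and compound 2 (`Clc1ccc(Nc2nccs2)cc1OCC1=CCCC1`) gives 15000 nM. Compound 2 therefore holds the higher of the two numbers, and its gap to compound 1 lies beyond the usual scatter. Among the measured compounds shown here, these two compounds differ in more than one place, so the gap cannot be assigned to either change, and no measured single-change step is available as a guide.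

Compound 3 (`N#Cc1ccc(Nc2nccs2)cc1OCC1=CCCC1`) follows from compound 2 with cyano in place of chloro on an aromatic carbon. Its cyano group is shared with compound 1, and the rest of its structure with compound 2.

For the measured compounds named here, a step down in this assay is expected, of modest size and near the edge of the scatter, since the only measured compound carrying cyano is compound 1 at 4100 nM. The expected change is a 1.9-fold lower number from compound 2 to compound 3 (0.27 log units; within the scatter). For compound 3 the estimate is 8000 nM, with an expected range of 2500 nM to 20000 nM.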

Compound 3, half-maximal cytotoxic concentration: 1700 nM
Estimate against measurement, compound 3: 4.7-fold (0.67 log units) above; the whole stated range lies above it.
By their numbers in this assay, from the lowest: compound 3; then compound 1; then compound 2.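

At the aromatic carbon para to a (1,3-thiazol-2-yl)amino group, cyano in place of chloro now has a single-change reading in this assay: an 8.8-fold lower number from compound 2 to compound 3 (0.95 log units; beyond the scatter), so less compound is tolerated with cyano at this place when cyclopent-1-en-1-yl is held constant. With cyano held constant, cyclopent-1-en-1-yl in place of thiophen-2-yl gives a 2.4-fold lower number from compound 1 to compound 3 (0.38 log units; beyond the scatter), which shows that the group on the saturated chain carbon also moves the number and that cyclopent-1-en-1-yl does not by itself go with the higher number of compound 2. No measurement in hand accounts for either step.

The compounds shown leave open whether the chloro-to-cyano step keeps its size with thiophen-2-yl on the chain, since both steps so far run through compound 3. They also leave open how this aromatic carbon responds to other groups, such as a primary amide, a methoxy group or a hydrogen, and whether a longer chain on the oxygen changes the picture.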